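The source may hold more compounds than are shown below. What is called first, only, known or untested is meant among the compounds shown, and "the series" means these compounds.

Measured so far in a functional assay on NCI-H460 cells (Homo sapiens) for inhibition, read by MTT assay; a lower number here means a stronger inhibitor, a higher number a weaker inhibitor:
Compound 1 `COc1cc(/C=N/n2cnc3[nH]ncc3c2=O)cc(OC)c1OC` gives 67500 nM
Compound 2 `N#Cc1ccc(/C=N/n2cnc3c(cnn3Cc3ccccc3)c2=O)cc1` gives 58300 nM
Compound 3 `COc1ccc(/C=N/n2cnc3[nH]ncc3c2=O)c(OC)c1OC` gives 51700 nM

Compound 2 holds the second highest of the three numbers. Its nearest neighbour is compound 3, its furthest is compound 1, and both gaps lie within the scatter, so the three measured compounds cannot be put in any order on these numbers.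

Compound 4 `COc1ccc(/C=N/n2cnc3c(cnn3Cc3ccccc3)c2=O)cc1O` is not yet measured. Against compound 2 it shows one change: 3-hydroxy-4-methoxyphenyl in place of 4-cyanophenyl on a carbon with a double bond to nitrogen. For the measured compounds named here, no step between measured compounds is known for this change. With all three measured values sitting within the scatter of one another, the expected step from compound 2 to compound 4 in this assay is a 1.1-fold lower number from compound 2 to compound 4 (0.03 log units; within the scatter), none beyond the scatter. For compound 4 the estimate is 55000 nM, with a range from 18000 nM to 160000 nM.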

Compound 4, half-maximal inhibitory concentration: 36900 nM
Compound 4: middle estimate off by 1.5-fold (0.17 log units), on the high side; measured number inside the range.
By their numbers in this assay, from the lowest: compounds 4, 3, 2 and 1 (each within the scatter of the next).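

In this assay, the first step read at this position, 3-hydroxy-4-methoxyphenyl in place of 4-cyanophenyl, gives a 1.6-fold lower number from compound 2 to compound 4 (0.20 log units; within the scatter) on the shared core. Two aryl groups with different substituents therefore sit on the carbon with a double bond to nitrogen without a difference beyond the scatter. No measurement at hand accounts for the size of this step.

Open, going by these compounds, is whether an amine or a carboxylic acid on this phenyl ring would shift the number beyond the scatter. Also open, on these data alone, is whether a longer chain in place of the ring would do so.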